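Para-substituent swap on the aryl sulfonyl piperazine series

A few compounds are considered here, and "the series" means these few. Any claim that something is new, unique, unknown or untested is made for them only; others in the source may bear on it.

Measured so far:
compound 1 `COc1cc2nc(N3CCN(S(=O)(=O)c4ccc(Br)cc4)CC3)nc(N)c2cc1OC`: 20000 nM
compound 2 `COc1cc2nc(N3CCN(S(=O)(=O)c4ccc(OC(F)(F)F)cc4)CC3)nc(N)c2cc1OC`: 25000 nM

For the measured compounds named here, in a functional assay on PC-3 cells (Homo sapiens) for inhibition (on this read-out higher numbers stand for weaker inhibition and lower numbers for stronger inhibition), compound 2 gives the highest of the two numbers; its only neighbour is compound 1, and the step of a 1.3-fold higher number from compound 1 to compound 2 (0.10 log units; within the scatter) stays within the scatter. Compound 3 `COc1cc2nc(N3CCN(S(=O)(=O)c4ccc(C(C)(C)C)cc4)CC3)nc(N)c2cc1OC` differs from compound 2 by tert-butyl in place of trifluoromethoxy on an aromatic carbon. Going by the values given here, the only measured step that bears on this, the exchange of the para group from compound 1 to compound 2, produced no movement beyond the scatter, so another exchange of the para group is expected to give no step beyond the scatter in this assay, a 1.1-fold lower number from compound 2 to compound 3 (0.06 log units; within the scatter). Compound 3 is therefore estimated at 22000 nM, within 9000 nM to 55000 nM.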

Compound 3, half-maximal inhibitory concentration: 4100 nM
Beside the measured number, compound 3's estimate is 5.4-fold (0.73 log units) above it; measured number outside the range, below it.
By their numbers in this assay, from the lowest: compound 3; then compounds 1 and 2 (each within the scatter of the next).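

In this assay, for the compounds shown here, this aromatic position turns out to respond to the choice of group: tert-butyl gives a 6.1-fold lower number from compound 2 to compound 3 (0.79 log units; beyond the scatter) and a 4.9-fold lower number from compound 1 to compound 3 (0.69 log units; beyond the scatter), the first steps beyond the scatter. Bromo and trifluoromethoxy remain within the scatter of each other, so only tert-butyl stands apart among the three groups. No available data explain this difference.

From the compounds shown here alone, whether the lower number is specific to tert-butyl remains open. An isopropyl group, a longer alkyl chain, an amine or a carboxylic acid at this position would help define the trend.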